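Adding a Second Chloro Group: Expected Cytotoxicity

The source may hold more compounds than are shown below. What is called first, only, known or untested is meant among the compounds shown, and "the series" means these compounds.

Compound 1 `Nc1sc2c(c1-c1nc3ccccc3s1)CCCC2` and compound 2 `Nc1sc2c(c1-c1nc3cc(Cl)ccc3s1)CCCC2` share a core, and compound 2 carries one change: chloro in place of hydrogen on an aromatic carbon In an ADME assay on HepG2 cells (Homo sapiens) for cytotoxicity, read by MTT assay, with a stated time of 72 h (on this read-out lower numbers stand for higher toxicity in this test and higher numbers for lower toxicity in this test), compound 1 gives 163 ug/mL while compound 2 gives 93.7 ug/mL, so a 1.7-fold lower number from compound 1 to compound 2 (0.24 log units; within the scatter).

Compound 3 `Clc1ccccc1/C=N/c1sc2c(c1-c1nc3ccccc3s1)CCC2` has a different core, and the difference between the two cores is not broken down here. In this assay compound 3 gives 180 ug/mL, a number close to that of compound 1 and of compound 2, all three lying within the usual scatter of one another.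

Compound 4 `Clc1ccc(/C=N/c2sc3c(c2-c2nc4ccccc4s2)CCC3)c(Cl)c1` has not yet been measured. Within the data shown here, it differs from compound 3 by chloro in place of hydrogen on an aromatic carbon This is the same kind of change as the one from compound 1 to compound 2, but the surroundings differ: in compound 2 the new chloro sits on a ring that is part of a fused or bridged system of two rings, meta to a fused ring and para to a fused ring, whereas in compound 4 it sits on a six-membered aromatic ring of carbon only, meta to a chloro group and para to a large group.

The step of a 1.5-fold lower number from compound 3 to compound 4 (0.18 log units; within the scatter) is expected to be small, because the earlier step of a 1.7-fold lower number from compound 1 to compound 2 (0.24 log units; within the scatter) stayed within the scatter. Compound 4 is therefore estimated at 120 ug/mL in this assay, most likely between 60 ug/mL and 240 ug/mL.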

Compound 4, half-maximal cytotoxic concentration: 310 ug/mL
Compound 4: the middle estimate sits 2.6-fold (0.41 log units) below what was measured, outside the stated range (above it).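

In this assay, turning the 2-chlorophenyl group into a 2,4-dichlorophenyl group gives a 1.7-fold higher number from compound 3 to compound 4 (0.24 log units; within the scatter). Set beside the earlier step, the same swap of hydrogen for chloro does not carry over from one core to the other with the same direction and size: the same change on two cores in this assay, a 1.7-fold lower number (0.24 log units; within the scatter) from compound 1 to compound 2 and a 1.7-fold higher number (0.24 log units; within the scatter) from compound 3 to compound 4, 3.0-fold (0.48 log units) apart, beyond the scatter of two such steps Each step on its own stays within the scatter, and neither shows that chloro by itself shifts the number in this test; only the gap between the two steps stands out, and with a single pair on each core it does not show whether the core, the ring that takes up the chloro or something else lies behind that gap.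

The compounds shown leave open whether a fluoro, methoxy or amine group on the 2-chlorophenyl group of compound 3 would give a step like the one to compound 4. Going by these compounds, it also remains open whether chloro at other places on that group, or on further cores, would follow either of these two steps, as two pairs are too few to set a rule for the series.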